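This account rests on a few compounds, and the source may have more. Where it says the series, first, only, none or still open, it means among the compounds named here.

In a functional assay on DU-145 cells (Homo sapiens) for cytotoxicity, read by MTT assay, with a stated time of 72 h (a higher number here means a weaker inhibitor, a lower number a stronger inhibitor), three compounds have been measured. Compound 1 (`CC(C)NC(=S)N/N=C1\CC(c2ccc(O)cc2)Oc2cc(O)ccc21`) gives 60400 nM and compound 2 (`CC(C)(C)NC(=S)N/N=C1\CC(c2ccc(O)cc2)Oc2cc(O)ccc21`) gives 42900 nM, while compound 3 (`Oc1ccc(C2C/C(=N\NC(=S)N3CCCC3)c3ccc(O)cc3O2)cc1`) gives 51700 nM and so stands within the scatter of both others. Compound 4 (`CCCN(CCC)C(=S)N/N=C1\CC(c2ccc(O)cc2)Oc2cc(O)ccc21`) has not yet been measured. It has dipropylamino in place of pyrrolidin-1-yl on a thiocarbonyl carbon. Two measured steps exchange the group on that same carbon (a 1.2-fold lower number from compound 1 to compound 3 (0.07 log units; within the scatter)) and (a 1.2-fold higher number from compound 2 to compound 3 (0.08 log units; within the scatter)). A third places methyl in place of hydrogen on a saturated chain carbon (a 1.4-fold lower number from compound 1 to compound 2 (0.15 log units; within the scatter)). Going by the values given here, all three steps are small and lie within the scatter, although no measured compound carries dipropylamino, so the comparison is indirect. No step beyond the scatter is therefore expected in this assay, and the estimated step is small (a 1.1-fold lower number from compound 3 to compound 4 (0.06 log units; within the scatter)). The expected value for compound 4 is 45000 nM with an estimated range from 22000 nM to 90000 nM as the outcome.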

Compound 4, half-maximal inhibitory concentration: 62100 nM
Beside the measured number, compound 4's estimate is 1.4-fold (0.14 log units) below it, within the range that was stated.
By their numbers in this assay, from the lowest: compounds 2, 3, 1 and 4 (each within the scatter of the next).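

In this assay, exchanging the pyrrolidin-1-yl ring for the open-chain dipropylamino group on the thiocarbonyl carbon gives a 1.2-fold higher number from compound 3 to compound 4 (0.08 log units; within the scatter). The exchanges of the (tert-butyl)amino and isopropylamino groups for dipropylamino also stay within the scatter, with a 1.4-fold higher number from compound 2 to compound 4 (0.16 log units; within the scatter) and a 1.0-fold higher number from compound 1 to compound 4 (0.01 log units; within the scatter), so this group with two propyl chains joins the ring and both monoalkylamino groups in a set that the assay does not separate. The data offered contain nothing that accounts for this lack of separation.

On these data alone, it remains open whether a group of another kind on that carbon, such as an anilino group or a morpholin-4-yl ring, or one carrying a carboxylic acid, would produce a step beyond the scatter. The compounds shown also leave open how changes to the shared core, including its hydroxyl groups, would register in this assay.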